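Ethylamino for piperidinyloxy beside the primary amide

The source may hold more compounds than are shown below. What is called first, only, known or untested is meant among the compounds shown, and "the series" means these compounds.

Three compounds of the series have numbers in an assay on cells for inhibition of MAP kinase-interacting serine/threonine-protein kinase 1 (Homo sapiens), read by mobility shift assay, with stated times of 10 min and 60 min, in the presence of a further agent that is not named here; a lower number here means a stronger inhibitor, a higher number a weaker inhibitor. Compound 1 `NC(=O)c1ccc(-c2cccnc2)cc1OC1CCNCC1` gives 1100 nM. Compound 2 `CC(=O)c1cncc(-c2ccc(C(N)=O)cc2)c1` gives 8000 nM. Compound 3 `Cc1c(-c2cncc(-c3ccc(C(N)=O)c(OC(C)C)c3)c2)cnn1C` gives 60 nM. On these numbers compound 1 stands second highest of the three: compound 2 is its nearer neighbour, with a number higher than that of compound 1 by more than the scatter, and compound 3 is the furthest, with a number lower than that of compound 1 by well more than the scatter.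

Compound 4 `CCNc1cc(-c2cccnc2)ccc1C(N)=O` has not yet been measured in this assay. It differs from compound 1 in one place: ethylamino in place of (piperidin-4-yl)oxy on an aromatic carbon. Going by the values given here, no pair of measured compounds differs in the same way, so nothing measured gives the size of this step directly. Among the compounds with values here, compound 3, the one with the lowest number, carries an isopropoxy group on its carboxamide-bearing ring, but it also differs from compound 1 elsewhere, so it is no clean guide.

The step from compound 1 to compound 4 is expected to be a 1.8-fold lower number from compound 1 to compound 4 (0.26 log units; within the scatter), toward a lower number, and may not go beyond the scatter. For compound 4 in this assay the estimate is 600 nM, with a range from 120 nM to 3000 nM.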

Compound 4, half-maximal inhibitory concentration: 58000 nM
Beside the measured number, compound 4's estimate is 97-fold (1.99 log units) below it, and the stated range ends below it.
By their numbers in this assay, from the lowest: compound 3; then compound 1; then compound 2; then compound 4.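

Working from this assay, the aromatic carbon ortho to the carbamoyl group and meta to the pyridin-3-yl group is sensitive to what it carries: ethylamino in place of (piperidin-4-yl)oxy gives a large step (a 53-fold higher number from compound 1 to compound 4 (1.72 log units; beyond the scatter)), the first single-place change in the series whose size can be read. This one step changes several things at once, since the six-membered non-aromatic ring is lost, the group becomes smaller, and the atom attached to the aromatic carbon changes from oxygen to nitrogen, so the number cannot be assigned to any one of these. Nothing available here accounts for the loss seen with ethylamino.

Still open, from the compounds shown here alone, is which of these features carries the step: an ethoxy group at this carbon would keep the oxygen link without the ring, while a (piperidin-4-yl)amino group would keep the ring on a nitrogen link. Also open, going by these compounds, is whether a step of this size holds on a core carrying another group in place of pyridin-3-yl, such as a pyrazole or a phenyl ring.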